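Methoxy-methyl aryl variant of a piperazine aorta antagonist

The compounds below may be only part of what the source reports. "The series", "measured", "known", "first", "only" and "open" are said of these compounds alone.

compound 1 `CN(C)C(=O)c1cccnc1NCCCN1CCN(c2ccccc2-c2ncco2)CC1`: 25.1 nM
compound 2 `CSc1ccccc1N1CCN(CCCNc2ncccc2C(=O)N(C)C)CC1`: 31.6 nM
compound 3 `CN(C)C(=O)c1cccnc1NCCCN1CCN(c2ccccc2Cc2ccccc2)CC1`: 79.4 nM

In a functional assay on aorta for antagonist activity at Alpha-1D adrenergic receptor (Rattus norvegicus) (on this read-out lower numbers stand for tighter binding and higher numbers for weaker binding), compound 2 gives the second highest of the three numbers; it sits nearest to compound 1, within the scatter, and furthest from compound 3. Compound 4 `COc1cc(C)ccc1N1CCN(CCCNc2ncccc2C(=O)N(C)C)CC1` is not yet measured. It differs from compound 2 in one place: 2-methoxy-4-methylphenyl in place of 2-(methylsulfanyl)phenyl on an amine nitrogen in a ring. Going by the values given here, two measured steps bear on this position. The step of a 1.3-fold higher number from compound 1 to compound 2 (0.10 log units; within the scatter) was within the scatter, while the step of a 2.5-fold higher number from compound 2 to compound 3 (0.40 log units; beyond the scatter) was modest. Small groups on this aryl ring thus gave similar numbers, and only the benzyl case moved beyond the scatter. Compound 4 is therefore expected to show no step beyond the scatter, a 1.1-fold lower number from compound 2 to compound 4 (0.02 log units; within the scatter), with an estimated value of 30 nM in a range from 12 nM to 80 nM.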

Compound 4, dissociation constant: 39.8 nM
Compound 4: the middle estimate sits 1.3-fold (0.12 log units) below what was measured; the measured number falls inside the stated range.
By their numbers in this assay, from the lowest: compounds 1, 2, 4 and 3 (each within the scatter of the next, the first and the last beyond it).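

In this assay, 2-methoxy-4-methylphenyl in place of 2-(methylsulfanyl)phenyl gives a 1.3-fold higher number from compound 2 to compound 4 (0.10 log units; within the scatter) on the amine nitrogen in a ring. The earlier steps shown here changed only a group on an aromatic carbon, whereas this one replaces the whole aryl group, sulfur for oxygen and with an added methyl, and stays within the scatter. No measured evidence accounts for this result.

The compounds shown leave open whether methoxy or methyl alone would give a similar number. They also leave open how a carboxylic acid or an amine on this aryl ring would read.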